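This account rests on a few compounds, and the source may have more. Where it says the series, first, only, none or still open, it means among the compounds named here.

Measured in an assay on cells for displacement of a labelled ligand from prostaglandin E2 receptor EP4 subtype (Homo sapiens), read by scintillation counting; on this read-out higher numbers stand for weaker inhibition and lower numbers for stronger inhibition:

compound 1 `Cc1oc(C(=O)O)cc1CCOc1ccc(-c2ccccc2)cc1`: 3800 nM
compound 2 `Cc1oc(C(=O)NS(=O)(=O)c2ccccc2)cc1COc1ccc(-c2ccccc2)cc1`: 25 nM
compound 3 `COc1ccc(-c2ccc(OCc3cc(C(=O)NS(=O)(=O)c4cccs4)oc3C)cc2)cc1`: 3.6 nM

Among these three, compound 3 gives the lowest number, and its gaps to compound 2 and to compound 1 both lie beyond the usual scatter of this assay. Compound 4 `COc1ccc(-c2ccc(OCc3cc(C(=O)NS(=O)(=O)c4ccc(CN)cc4)oc3C)cc2)cc1` is not yet measured; it differs from compound 3 only in one place: 4-(aminomethyl)phenyl in place of thiophen-2-yl on a sulfonyl sulfur. Within the data shown here, no measured pair shows this same change, so the expectation rests on compound 3 alone. A small rise in this assay, at most slightly beyond the scatter, is expected, which means a step of a 2.5-fold higher number from compound 3 to compound 4 (0.40 log units; beyond the scatter). Compound 4 is therefore estimated at 9 nM, with a plausible range from 2.5 nM to 35 nM.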

Compound 4, inhibition constant: 100 nM
For compound 4 the middle estimate is 11-fold (1.05 log units) below the measured one; the whole stated range lies below it.
By their numbers in this assay, from the lowest: compound 3; then compound 2; then compound 4; then compound 1.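

In this assay the group on the sulfonyl sulfur clearly matters: replacing thiophen-2-yl with 4-(aminomethyl)phenyl brings a 28-fold higher number from compound 3 to compound 4 (1.44 log units; beyond the scatter) and this large step shows that this position does not treat these two aromatic groups alike. Nothing available explains the rise. The change swaps the ring and adds the aminomethyl group at once, so the compounds shown cannot separate the two. A methyl or hydroxymethyl group in place of the aminomethyl, on the same six-membered ring, would be needed to tell whether the ring or its amine accompanies the rise.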